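The source may report more compounds than this note shows. Statements on the series, on what has been measured and on what is new or still open speak of the compounds shown alone.

Of the compounds shown here, three of a shared core have been measured so far in a functional assay on BT-474 cells (Homo sapiens) for inhibition; on this read-out lower numbers stand for stronger inhibition and higher numbers for weaker inhibition. Compound 1 `Cc1cnc(CN2CC(=O)N(CC(C)C)c3c(Cl)nc(N)nc32)c(C)c1Br` gives 130 nM. Compound 2 `COc1c(C)cnc(CN2CC(=O)N(C(C)C)c3c(Cl)nc(N)nc32)c1C` gives 30 nM. Compound 3 `COc1c(C)cnc(CN2CC(=O)N(C(C)C(=O)NCCN(C)C)c3c(Cl)nc(N)nc32)c1C` gives 60 nM. Among these three numbers compound 3 stands second highest: compound 2 is nearest to it, and the gap between them is within the scatter, while compound 1 is furthest, with a number that lies beyond the scatter above that of compound 3.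

The next compound, compound 4 `COc1c(C)cnc(CN2CC(=O)N(CCN3CCCC3)c3c(Cl)nc(N)nc32)c1C`, differs from compound 3 in one place: 2-(pyrrolidin-1-yl)ethyl in place of 1-((2-(dimethylamino)ethyl)carbamoyl)ethyl on an amide-type nitrogen in a ring.

Among the compounds with values here, only one measured step speaks to this position. That step, a 2.0-fold higher number from compound 2 to compound 3 (0.30 log units; within the scatter), also swapped the group on the same amide-type nitrogen in a ring, and it stayed within the scatter. Within the data shown here, compounds 1 and 2 differ in two places, so their values show only that this core tolerates several substituent patterns. The change to compound 4 is therefore expected to move this assay little, with no direction beyond the scatter, giving a 1.5-fold lower number from compound 3 to compound 4 (0.18 log units; within the scatter). Compound 4 is expected to give about 40 nM in this assay, within a range from 15 nM to 120 nM.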

Compound 4, half-maximal inhibitory concentration: 520 nM
For compound 4 the middle estimate is 13-fold (1.11 log units) below the measured one, outside the stated range (above it).
By their numbers in this assay, from the lowest: compounds 2 and 3 (each within the scatter of the next); then compound 1; then compound 4.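

The amide-type nitrogen in a ring turns out to be far less forgiving than the earlier swap suggested: in this assay the new group gives an 8.7-fold higher number from compound 3 to compound 4 (0.94 log units; beyond the scatter) and, set against isopropyl, it gives a 17-fold higher number from compound 2 to compound 4 (1.24 log units; beyond the scatter) on the same shared core. Group size alone does not follow these numbers, since the 1-((2-(dimethylamino)ethyl)carbamoyl)ethyl group, which has more heavy atoms than 2-(pyrrolidin-1-yl)ethyl, gave only a 2.0-fold higher number from compound 2 to compound 3 (0.30 log units; within the scatter) while the group with fewer heavy atoms gave the larger step. No measurement at hand accounts for the difference between these groups.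

The change to compound 4 removes the carbonyl and the amide hydrogen and also brings in a five-membered ring, so the compounds shown cannot say which of these parts goes with the higher number. A plain 2-(dimethylamino)ethyl group on the same nitrogen would keep the open-chain amine without the carbonyl, and a pyrrolidine amide would keep the carbonyl together with the ring, so the two would begin to separate these parts.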